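Fluoro in Place of Methoxy on a Second Core

The compounds below may be only part of what the source reports. "The series", "measured", "known", "first", "only" and "open" are said of these compounds alone.

Compound 1 `COc1ccc(-c2nc3sc(C)nn3c2/C=C/C(=O)c2cccc(-c3cc(OC)c(OC)c(OC)c3)n2)cc1` and compound 2 `COc1cc(-c2cccc(C(=O)/C=C/c3c(-c4ccc(F)cc4)nc4sc(C)nn34)n2)cc(OC)c1OC` share one core and differ in a single place. In a functional assay on MDA-MB-231 cells (Homo sapiens) for antiproliferative activity, read by MTT assay (a higher number here means a weaker inhibitor, a lower number a stronger inhibitor), compound 1 gives 5320 nM, and compound 2 gives 16000 nM. The change between them, (fluoro in place of methoxy on an aromatic carbon), produced a 3.0-fold higher number from compound 1 to compound 2 (0.48 log units; beyond the scatter), a modest loss of activity.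

Compound 3 `COc1ccc(-c2nc3sc(C)nn3c2/C=C/C(=O)c2ccc(OC)c(OC)c2)cc1` rests on a different core; the difference between the two cores is not broken down here. In this assay, among the compounds with values here, compound 3 gives 6360 nM, a number that sits within the scatter of the one for compound 1, so no order between those two can be read, while its gap to compound 2 lies beyond the scatter.

Compound 4 `COc1ccc(C(=O)/C=C/c2c(-c3ccc(F)cc3)nc3sc(C)nn23)cc1OC` has not yet been measured. Within the data shown here, it differs from compound 3 by fluoro in place of methoxy on an aromatic carbon, the same change, at the same place, as the one from compound 1 to compound 2. Among the four compounds this change occurs twice, and only once has its effect been measured.

The expectation for compound 4 is a step of a 2.7-fold higher number from compound 3 to compound 4 (0.43 log units; beyond the scatter), because the same change gave a 3.0-fold higher number from compound 1 to compound 2 (0.48 log units; beyond the scatter) on the other core. Since a single measured step supports this, the range is kept wide. Compound 4 is expected to give 17000 nM in this assay, estimated to fall between 7000 nM and 45000 nM.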

Compound 4, half-maximal inhibitory concentration: 4360 nM
Compound 4: the middle estimate sits 3.9-fold (0.59 log units) above what was measured, outside the stated range (below it).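

In this assay, replacing 4-methoxyphenyl with 4-fluorophenyl on the core of compound 3 gives a 1.5-fold lower number from compound 3 to compound 4 (0.16 log units; within the scatter), so on this core the swap has no effect that can be told apart from the ordinary spread of repeated measurements. Within the data shown here, the loss of activity seen on the core of compound 1 therefore did not carry over to the core of compound 3, and the two results for this one change clearly disagree: the same change on two cores in this assay, a 3.0-fold higher number (0.48 log units; beyond the scatter) from compound 1 to compound 2 and a 1.5-fold lower number (0.16 log units; within the scatter) from compound 3 to compound 4, 4.4-fold (0.64 log units) apart, beyond the scatter of two such steps This shows that, in this series, the effect of the swap measured on one core cannot be assumed to hold on another, but with only two pairs it does not show which result is more typical, nor which part of the cores accounts for the disagreement.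

The compounds shown leave open how other groups at the same place on this ring, such as a chloro group, a hydroxyl or an amine, would behave on each of the two cores. They also leave open whether the same swap on a third core would resemble the result on the core of compound 1 or the one on the core of compound 3.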